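The source may hold more compounds than are shown below. What is called first, only, known or untested is meant among the compounds shown, and "the series" means these compounds.

Three compounds that share one core were tested in an assay on isolated protein for inhibition of Dipeptidyl peptidase 9 (Homo sapiens); on this read-out higher numbers stand for weaker inhibition and lower numbers for stronger inhibition. Compound 1 `CC#CCn1c(N2CCC[C@@H](N)C2)cc(=O)n(Cc2ccc3ccc(Cl)cc3n2)c1=O` gives only a limit of the assay, > 100000 nM. Compound 2 `CC#CCn1c(N2CCC[C@@H](N)C2)cc(=O)n(CC#CC)c1=O` likewise gives a limit, > 100000 nM. Compound 3 `CC#CCn1c(N2CCC[C@@H](N)C2)cc(=O)n(Cc2ccc3cc(OC)ccc3n2)c1=O` also gives a limit, > 100000 nM. Compound 3 thus stands at the limit of > 100000 nM in this assay, at which 3 of the 3 values shown sit, and nothing separates the three compounds on this read-out. Compound 4 `CC#CCn1c(N2CCC[C@@H](N)C2)cc(=O)n(Cc2ccc3cc(Br)ccc3n2)c1=O` differs from compound 3 by bromo in place of methoxy on an aromatic carbon. Among the measured compounds shown here, with no measured step to lean on, the expected change in this assay is a step that the limit leaves unreadable from compound 3 to compound 4, nothing beyond the scatter. Compound 4 is therefore estimated at 150000 nM, with a range from 50000 nM to 500000 nM, and most likely again only a limit.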

Compound 4, half-maximal inhibitory concentration: > 100000 nM
Compound 4: a limit, no number (the forecaster's own chance of this, stated with the estimate: 85%); the middle value is on the limit's open side.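

The step from compound 3 to compound 4 cannot be read, since both compounds give only a limit: the limit of > 100000 nM in this assay, at which 4 of the 4 values shown sit.

The compounds shown leave open how strongly any of them inhibits, and which change to the shared core would give a measurable number.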